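The compounds below may be only part of what the source reports. "The series", "measured", "known", "first", "only" and "open" are said of these compounds alone.

- Compound 1 `COc1ccc(-c2cc(O)c3cccnc3n2)cc1`: 53700 nM
- Compound 2 `Cc1cnc2nc(-c3ccc(Cl)cc3)cc(O)c2c1`: 3020 nM

In a functional assay on U-251 cells (Homo sapiens) (a lower number here means a stronger inhibitor of growth, a higher number a weaker inhibitor of growth), compound 2 has the lower of the two numbers at 3020 nM, and its gap to compound 1 lies beyond the scatter. Compound 3 `COc1ccc(-c2cc(O)c3cc(C)cnc3n2)cc1` has methoxy in place of chloro on an aromatic carbon, para to a large group (methoxy in place of chloro on an aromatic carbon). Within the data shown here, no measured pair shows this change alone. Compound 1 also carries methoxy and gives 53700 nM, so a moderate rise in the number, beyond the scatter, is expected. The expected change is a 4.0-fold higher number from compound 2 to compound 3 (0.60 log units; beyond the scatter). For compound 3, the estimated value is 12000 nM, with an expected range of 4000 nM to 40000 nM.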

Compound 3, concentration for 50% growth inhibition: 4170 nM
Estimate against measurement, compound 3: 2.9-fold (0.46 log units) above; the measured number falls inside the stated range.
By their numbers in this assay, from the lowest: compounds 2 and 3 (each within the scatter of the next); then compound 1.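

In this assay, the change from chloro to methoxy gives a 1.4-fold higher number from compound 2 to compound 3 (0.14 log units; within the scatter) and so, with the methyl present, does not separate the two compounds. Methyl in place of hydrogen on an aromatic carbon gives a 13-fold lower number from compound 1 to compound 3 (1.11 log units; beyond the scatter) and is the first single change here with a large effect, which shows that this position matters on the methoxy series. Nothing available explains either step. The compounds shown leave open whether the methyl has the same effect with chloro in place of methoxy, and how an amine or a longer chain at the methyl position would compare.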